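Propyl for ethyl on the core: one step, one forecast

A few compounds are considered here, and "the series" means these few. Any claim that something is new, unique, unknown or untested is made for them only; others in the source may bear on it.

Compound 1, `CCn1nc(-c2ccnc(Nc3cccc(S(N)(=O)=O)c3)n2)c2ccccc21`, is measured in a functional assay on HCT-116 cells (Homo sapiens) for antiproliferative activity, read by MTT assay, with a stated time of 72 h; a higher number here means a weaker inhibitor of growth, a lower number a stronger inhibitor of growth; in that assay compound 1 gives 9010 nM. Compound 2, `CCn1nc(-c2ccnc(Nc3ccc(O)cc3)n2)c2ccccc21`, gives 5290 nM in this assay, and compound 3, `CCCn1nc(-c2ccnc(Nc3ccc(O)cc3)n2)c2ccccc21`, gives 5450 nM there. The values of compound 1, compound 2 and compound 3 all lie within the scatter of one another, so no order among them is claimed. How the core of compound 1 differs from that of compound 2 is not broken down here.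

Within the pair compound 2 and compound 3 one change is made: methyl in place of hydrogen on a saturated chain carbon, two bonds along the chain from an aromatic nitrogen. Its step in this assay is a 1.0-fold higher number from compound 2 to compound 3 (0.01 log units; within the scatter), flat by any reading.

Compound 4, `CCCn1nc(-c2ccnc(Nc3cccc(S(N)(=O)=O)c3)n2)c2ccccc21`, awaits measurement in this assay. It differs from compound 1 by methyl in place of hydrogen on a saturated chain carbon, two bonds along the chain from an aromatic nitrogen, the same change, at the same place, as that between compound 2 and compound 3. For the measured compounds named here, the one measured instance of this change gives nothing to lean on for a shift in either direction, and the two cores cannot be compared beyond the fact that their values sit within the scatter.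

On that basis the step from compound 1 to compound 4 is expected to be a 1.0-fold higher number from compound 1 to compound 4 (0.00 log units; within the scatter), resting on compound 2 and compound 3 with their step of a 1.0-fold higher number from compound 2 to compound 3 (0.01 log units; within the scatter). Compound 4 is therefore estimated at 9100 nM, with a likely range from 4500 nM to 18500 nM.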

Compound 4, concentration for 50% growth inhibition: 7950 nM
For compound 4 the middle estimate is 1.1-fold (0.06 log units) above the measured one; measured number inside the range.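

Methyl in place of hydrogen on a saturated chain carbon, two bonds along the chain from an aromatic nitrogen, gives in this assay a 1.1-fold lower number from compound 1 to compound 4 (0.05 log units; within the scatter), so ethyl to propyl on the core of compound 1 produces no shift that can be told from the scatter. Set beside the earlier pair, the change carries from one core to the other with no difference that can be read: the same change on two cores in this assay, a 1.0-fold higher number (0.01 log units; within the scatter) from compound 2 to compound 3 and a 1.1-fold lower number (0.05 log units; within the scatter) from compound 1 to compound 4, 1.2-fold (0.07 log units) apart, within the scatter of two such steps. For the compounds shown here, this shows only that a flat step recurs on two cores in one cell assay; it does not show that the change is silent in general, it cannot reveal any influence of the core on a step that is flat in both pairs, and it gives no reason for the flatness.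

The compounds shown leave open whether the flat result holds for a longer chain such as butyl, for a branched chain such as isopropyl, or for a chain ending in a hydroxyl or an amine. Also open, going by these compounds, is whether ethyl to propyl stays flat on a core carrying a carboxylic acid or an amide in place of the sulfonamide of compound 1 or the hydroxyl of compound 2.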